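Amine chain extension in a succinimide-linked carboxylic acid series

A few compounds are considered here, and "the series" means these few. Any claim that something is new, unique, unknown or untested is made for them only; others in the source may bear on it.

Measured in an assay on CHO cells for displacement of a labelled ligand from C-X-C chemokine receptor type 3 (Homo sapiens), with a stated time of 60 min; a lower number here means a stronger inhibitor, a higher number a weaker inhibitor:
compound 1, `C[C@@H](c1ccc(Cl)cc1)N(Cc1ccc(OCCN2C(=O)CCC2=O)c(C(=O)O)c1)CC1CCCC1`, 6600 nM
compound 2, `CCCN(Cc1ccc(OCCN2C(=O)CCC2=O)c(C)c1)C1c2ccc(Cl)cc2CC1C(=O)O`, 1350 nM
compound 3, `CCN(Cc1ccc(OCCN2C(=O)CCC2=O)c(C)c1)C(CC(=O)O)c1ccc(Cl)cc1`, 424 nM

Compound 3 has the lowest number of the three. Compound 2 sits nearest, with a number beyond the scatter above that of compound 3, and compound 1 is the furthest away. Compound 4, `CCCCN(Cc1ccc(OCCN2C(=O)CCC2=O)c(C)c1)C(CC(=O)O)c1ccc(Cl)cc1`, differs from compound 3 by ethyl in place of hydrogen on a saturated chain carbon, two bonds along the chain from an amine nitrogen. For the measured compounds named here, no measured pair shows this change on its own, so the step from compound 3 to compound 4 cannot be read from the data; the expectation is a step in this assay that stays within the scatter, or at most a small one in either direction. Compound 4 is estimated at 450 nM, with a range of 150 nM to 1400 nM, an expected step of a 1.1-fold higher number from compound 3 to compound 4 (0.03 log units; within the scatter).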

Compound 4, half-maximal inhibitory concentration: 61 nM
Compound 4: the middle estimate sits 7.4-fold (0.87 log units) above what was measured; the measured number lies below the stated range.
By their numbers in this assay, from the lowest: compound 4; then compound 3; then compound 2; then compound 1.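

In this assay, for the compounds shown here, the change from ethyl to butyl, on a saturated chain carbon two bonds along the chain from an amine nitrogen, gives a 7.0-fold lower number from compound 3 to compound 4 (0.84 log units; beyond the scatter) and supplies the first single-place comparison. This position is therefore sensitive to chain length, at least for this pair, and the added ethyl improves the number rather than leaving it unchanged. Nothing available here accounts for the step.

From the compounds shown here alone, whether a longer chain such as hexyl extends the gain or reverses it remains open. Also open, going by these compounds, is whether a terminal hydroxyl or amine on the butyl chain would be tolerated.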